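The source may hold more compounds than are shown below. What is called first, only, known or untested is meant among the compounds shown, and "the series" means these compounds.

Two sulfonamides built on the same core have been measured in an assay on isolated protein for inhibition of malate dehydrogenase, mitochondrial (Sus scrofa), with stated times of 45 min and 30 min; on this read-out lower numbers stand for stronger inhibition and higher numbers for weaker inhibition. Compound 1 `O=S(=O)(Nc1ccc(-c2nc3ccccc3o2)cc1)c1cccs1` carries a thiophen-2-yl group on its sulfonyl sulfur. In this assay compound 1 gives only a limit, > 63000 nM, not a number. Compound 2 `O=S(=O)(Nc1ccc2oc(-c3ccccc3)nc2c1)c1ccc(F)c(C(F)(F)F)c1`, which places the sulfonamide at a different point of the core and carries a fluorinated, trifluoromethyl-bearing phenyl group, likewise reaches only a limit, > 63000 nM, in this assay. For the measured compounds named here, both results therefore sit at the limit of > 63000 nM in this assay, at which 2 of the 2 values shown sit, so compound 1 cannot be ranked against compound 2, and no step between measured compounds can be drawn.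

Compound 3 `O=S(=O)(Nc1ccc(-c2nc3ccccc3o2)cc1)c1ccccc1Cl` is not yet measured. It differs from compound 1 in one place: 2-chlorophenyl in place of thiophen-2-yl on a sulfonyl sulfur. Going by the values given here, because both values so far rest at the limit of > 63000 nM in this assay, at which 2 of the 2 values shown sit, no step beyond the scatter is expected from compound 1 to compound 3 in this assay, and the expected change is a step that the limit leaves unreadable from compound 1 to compound 3. For compound 3 the estimate in this assay is 100000 nM, within a range from 30000 nM to 400000 nM, with a high chance that only a limit is reported again.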

Compound 3, half-maximal inhibitory concentration: > 63000 nM
Compound 3: a limit, no number (the forecaster's own chance of this, stated with the estimate: 80%); the middle value is on the limit's open side.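

For the compounds shown here, compound 3 gives only a limit, not a number, in this assay, and so does compound 1, so no step from compound 1 to compound 3 can be read: the limit of > 63000 nM in this assay, at which 3 of the 3 values shown sit. The compounds shown leave open whether swapping thiophen-2-yl for 2-chlorophenyl on the sulfonyl sulfur changes inhibition at all, and what change to these compounds would give a measurable value.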